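The source may hold more compounds than are shown below. What is called first, only, known or untested is meant among the compounds shown, and "the series" means these compounds.

Of the compounds shown here, two sharing one core have numbers so far. In an in vitro ADME assay on microsomes from liver (Mus musculus) for pharmacokinetics, read by LC-MS, with a stated time of 10 min, tested at 1 uM (on this read-out higher numbers stand for fast clearance and lower numbers for slow clearance), compound 1 `CN1C[C@H](C(=O)Nc2ccc(Cl)cn2)[C@@H](c2ccc(/C=C/C(=O)Nc3ccccc3N)cc2)C1` gives 31 mL/min/kg and compound 2 `CCN1C[C@H](C(=O)Nc2ccc(Cl)cc2)[C@@H](c2ccc(/C=C/C(=O)Nc3ccccc3N)cc2)C1` gives 35 mL/min/kg on the same measurement. These numbers lie within the usual scatter of repeated measurements, so compound 2 stands level with compound 1.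

The next structure, compound 3 `CC(C)(CO)N1C[C@H](C(=O)Nc2ccc(Cl)cc2)[C@@H](c2ccc(/C=C/C(=O)Nc3ccccc3N)cc2)C1`, starts from compound 2 and puts 1-(hydroxymethyl)-1-methylethyl in place of ethyl on an amine nitrogen in a ring. The counted difference 1-(hydroxymethyl)-1-methylethyl in place of ethyl on an amine nitrogen in a ring is the whole change, and the rest of the molecule stays the same.

Among the measured compounds shown here, no pair of measured compounds differs in just one place, so the data offer no direct precedent for this swap and any forecast must stay loose. In this assay a small downward step is expected, one that does not clearly leave the scatter, starting from compound 2 at 35 mL/min/kg on the scale. The expected change is a 1.3-fold lower number from compound 2 to compound 3 (0.11 log units; within the scatter) in this estimate. Compound 3 is estimated at 27 mL/min/kg with an expected range from 13 mL/min/kg to 50 mL/min/kg for the measurement.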

Compound 3, clearance: 40 mL/min/kg
The estimate for compound 3 lay 1.5-fold (0.17 log units) below the measured number; the measured number falls inside the stated range.
By their numbers in this assay, from the lowest: compounds 1, 2 and 3 (each within the scatter of the next).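

Among the compounds shown here, this pair gives the first direct reading of a change on the amine nitrogen in the ring, since compound 1 differs from compound 2 in more than one place. In this assay, putting 1-(hydroxymethyl)-1-methylethyl in place of ethyl gives a 1.1-fold higher number from compound 2 to compound 3 (0.06 log units; within the scatter), so the read-out does not separate the two compounds, even though a group of 5 heavy atoms with 1 hydrogen-bond donor and 1 hydrogen-bond acceptor replaces one of 2 heavy atoms with neither. Nothing measured here accounts for this result.

The entering group combines a branched carbon with a hydroxyl, and this single step cannot show what each part contributes, whereas tert-butyl, which keeps the branching without the hydroxyl, or 2-hydroxyethyl, which keeps the hydroxyl without the branching, would pull the two apart. On these data alone, whether this nitrogen accepts other groups as evenly also stays open, for instance a longer chain or one ending in a carboxylic acid, and one pair cannot settle that.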